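This account rests on a few compounds, and the source may have more. Where it says the series, first, only, none or still open, it means among the compounds named here.

Compounds measured in a functional assay on HCT-116 cells (Homo sapiens) for cytotoxicity, read by MTT assay, with a stated time of 72 h; a lower number here means a stronger inhibitor, a higher number a weaker inhibitor:
- compound 1 `NCCCNc1c(C(=O)NCc2ccc(F)cc2)nc(Br)c2cccnc12`: 18000 nM
- compound 2 `N[C@H]1CC[C@H](Nc2c(C(=O)NCc3ccc(F)cc3)nc(Br)c3cccnc23)CC1`: 4000 nM
- compound 3 `O=C(NCCCNc1c(C(=O)NCc2ccc(F)cc2)nc(Br)c2cccnc12)c1ccccc1`: > 10000 nM

Compound 3 has no number in this assay, only a limit, > 10000 nM.

Compound 4 `CNCCCNc1c(C(=O)NCc2ccc(F)cc2)nc(Br)c2cccnc12` differs from compound 3 by a single change, methyl in place of benzoyl on an amine nitrogen.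

Within the data shown here, two measured steps bear on this change. The closer one is a step that the limit leaves unreadable from compound 1 to compound 3, which concerns the same amine nitrogen but gives no size to carry over. The other is a 4.5-fold lower number from compound 1 to compound 2 (0.65 log units; beyond the scatter). It lies elsewhere in the molecule, but it gives a rough idea of how far one change can move this series. With the benzoyl gone, compound 4 is expected to lie near compound 1, which gives 18000 nM. The direction from the limit cannot be read, and only a small change is expected: a step that the limit leaves unreadable from compound 3 to compound 4.

For compound 4 the estimated value is 14000 nM, with an expected range from 5000 nM to 40000 nM.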

Compound 4, half-maximal inhibitory concentration: > 10000 nM
Compound 4 was reported as a limit; the forecaster's own chance of this, stated with the estimate: 30%; the middle value is on the limit's open side.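

Compound 4 gives only a limit in this assay, > 10000 nM. Among these compounds, its one readable step is an at least 2.5-fold higher number from compound 2 to compound 4 (0.39 log units; beyond the scatter), so the 3-(methylamino)propyl chain does not match the 4-aminocyclohexyl group of compound 2 on the nitrogen on the aromatic ring. The steps from compound 1 and from compound 3 to compound 4 cannot be read, so neither methyl in place of hydrogen nor methyl in place of benzoyl on the amine nitrogen has a size, because the comparison stops at the limit: the limit of > 10000 nM in this assay, at which 2 of the 4 values shown sit.

As far as these compounds go, whether an acetyl or an ethyl group on this amine nitrogen would give a number instead of a limit stays open. So does whether a methyl group on the amine of the 4-aminocyclohexyl group would keep the level of compound 2.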